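The source may hold more compounds than are shown below. What is called first, only, known or untested is meant among the compounds shown, and "the series" means these compounds.

Measured compounds:
Compound 1 `O=C(CCCCC1CCSS1)Nc1ccc(OC(F)(F)F)cc1` gives 88.6%.
Compound 2 `O=C(CCCCC(S)CCS)Nc1ccccc1` gives "not determined" (no result reported).

In a functional assay on PC-3 cells (Homo sapiens) for inhibition, read by MTT assay, with a stated time of 24 h, tested at 100 ug/mL (a lower number here means less inhibition of growth, a higher number more inhibition of growth at the concentration tested), compound 1 gives 88.6%. For compound 2 the same assay gives no single number, so compound 2 cannot be placed on the scale at all. The piece follows the step from compound 2 to compound 3 `O=C(CCCCC(S)CCS)Nc1ccc(OC(F)(F)F)cc1`. The change is trifluoromethoxy in place of hydrogen on an aromatic carbon. Going by the values given here, with no number for compound 2, the size of this step in this assay cannot be read from the data; the only anchor is compound 1, whose value of 88.6% shows that a compound of this general build can give strong inhibition of growth. Taking that value as a guide, compound 3 is expected to reach about 75%, with a plausible range from 40% to 95%.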

Compound 3, percent growth inhibition at one concentration: 75.5%
Estimate against measurement, compound 3: 0.5 percentage points below, and the stated range covers the measured number.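

With trifluoromethoxy held in place, the open group with no ring, standing where the five-membered non-aromatic ring with 2 hetero atoms stood on the saturated chain carbon, gives a number 13.1 percentage points lower from compound 1 to compound 3 (beyond the scatter) in this assay at the concentration tested. This position therefore responds to the change, yet compound 3, at 75.5%, still shows strong inhibition of growth. No measurement is at hand that explains the difference between the two groups.

As far as these compounds go, the step from compound 2 to compound 3 cannot be read, and what trifluoromethoxy itself contributes on the aromatic carbon stays open. Also open, from the compounds shown here alone, is how an amine or a carboxylic acid on that aromatic carbon, or a longer chain leading to the carbonyl carbon, would read in this assay on this shared core.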